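From phenyl to 2,6-dichlorophenyl on a carbonyl carbon

This account rests on a few compounds, and the source may have more. Where it says the series, first, only, none or still open, it means among the compounds named here.

Compound 1 `COc1cc(/C=C/C(=O)c2cccc(NC(=O)c3ccccc3)c2)ccc1O`: 8.82 ug/mL
Compound 2 `COc1cc(/C=C/C(=O)c2cccc(NC(=O)c3cc(Cl)cc(Cl)c3)c2)ccc1O`: > 50 ug/mL (a limit, not a number)
Compound 3 `COC(=O)C(=O)Nc1cccc(C(=O)/C=C/c2ccc(O)c(OC)c2)c1`: 12.2 ug/mL

In a functional assay on U-87MG ATCC cells (Homo sapiens) for inhibition (on this read-out lower numbers stand for stronger inhibition and higher numbers for weaker inhibition), compound 1 holds the lowest of the two numbers shown. Compound 3 lies close to it, since a 1.4-fold higher number from compound 1 to compound 3 (0.14 log units; within the scatter) stays within the scatter. Compound 2 reached only the limit of this assay (the limit of > 50 ug/mL in this assay, at which 1 of the 3 values shown sits). Compound 4 `COc1cc(/C=C/C(=O)c2cccc(NC(=O)c3c(Cl)cccc3Cl)c2)ccc1O` differs from compound 1 as follows: 2,6-dichlorophenyl in place of phenyl on a carbonyl carbon. Within the data shown here, the one measured step that bears on this is an at least 5.6-fold higher number from compound 1 to compound 2 (0.75 log units; beyond the scatter), where two chlorines on the same ring at the same carbonyl carbon pushed the value to the limit. Compound 4 is therefore expected to give a weaker result, a 3.4-fold higher number from compound 1 to compound 4 (0.53 log units; beyond the scatter). The estimate for compound 4 is 30 ug/mL, within a range from 10 ug/mL to 100 ug/mL.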

Compound 4, half-maximal inhibitory concentration: 17.8 ug/mL
Estimate against measurement, compound 4: 1.7-fold (0.23 log units) above, and the stated range covers the measured number.
By their numbers in this assay, from the lowest: compounds 1, 3 and 4 (each within the scatter of the next). At a limit, above all of these: compound 2.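

In this assay, two chlorines on the phenyl at this carbonyl carbon do not by themselves move the number beyond the scatter: a 2.0-fold higher number from compound 1 to compound 4 (0.30 log units; within the scatter) and a 1.5-fold higher number from compound 3 to compound 4 (0.16 log units; within the scatter). The two dichlorophenyl groups do part: an at least 2.8-fold lower number from compound 2 to compound 4 (0.44 log units; beyond the scatter). Compound 2 and compound 4 both carry two chlorines on this ring. The data do not tell what sets the two results apart. The value of compound 2 is a limit, not a number.

From the compounds shown here alone, how a single chlorine on this ring would compare remains open. So does the effect of an amine or a carboxylic acid on the ring, or of a longer alkyl chain in its place.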